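Adding One Fluoro to Compound 2

The source may report more compounds than this note shows. Statements on the series, on what has been measured and on what is new or still open speak of the compounds shown alone.

- compound 1 `Cc1ccccc1Nc1nc(Nc2cccnc2)ncc1Cl` gives 38600 nM in a functional assay on Jurkat cells (Homo sapiens) for inhibition, read by CCK-8 assay, with a stated time of 48 h; on this read-out lower numbers stand for stronger inhibition of growth and higher numbers for weaker inhibition of growth
- compound 2 `CN1CCN(c2ccc(Nc3ncc(Cl)c(NCc4ccccc4)n3)nc2)CC1` gives > 100000 nM in this assay

Compound 2 reads > 100000 nM and this is a limit of the assay, not a number. Compound 3 `CN1CCN(c2ccc(Nc3ncc(Cl)c(NCc4ccc(F)cc4)n3)nc2)CC1` has not yet been measured. It differs from compound 2 in one place, with fluoro in place of hydrogen on an aromatic carbon and so benzyl becoming 4-fluorobenzyl. For the measured compounds named here, no two measured compounds differ in only one place, so the data show no direct example of what this swap does. The expectation is therefore a small step, perhaps toward stronger inhibition of growth, and possibly none beyond the scatter. Compound 3 keeps the rest of compound 2, which reads > 100000 nM as its limit, so it is expected to remain weak, and it may also return only a limit. The estimated change is an at least 1.1-fold lower number from compound 2 to compound 3 (0.04 log units; that floor lies within the scatter) on this reasoning. For compound 3 the estimate is 90000 nM with 35000 nM to 150000 nM as its expected range.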

Compound 3, concentration for 50% growth inhibition: > 100000 nM
Compound 3 ended at the assay's limit; the forecaster's own chance of this, stated with the estimate: 55%; at least 1.1-fold (0.04 log units) between middle value and limit.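

Compound 2 and compound 3 both end at a limit of the assay rather than at a number, so no step can be read between them: the limit of > 100000 nM in this assay, at which 2 of the 3 values shown sit. The compounds shown leave open whether fluoro in place of hydrogen changes inhibition of growth at all, and in which direction.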